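The source may report more compounds than this note shows. Statements on the series, on what has been measured and on what is new or still open speak of the compounds shown alone.

Measured in a functional assay on CHO-K1 cells with Glucose-dependent insulinotropic receptor (Homo sapiens) as the target, read by a luciferase reporter, with a stated time of 5 h; a lower number here means a smaller maximal response, a higher number a larger maximal response:

Compound 1 `CC(C)OC(=O)N1CCC(Oc2ncnc3c2CCN3c2ccc(S(C)(=O)=O)cc2F)CC1`: 91%
Compound 2 `CC(C)(C)OC(=O)N1CCC(Oc2ncnc3c2CCN3c2ccc(S(C)(=O)=O)cc2F)CC1`: 139%
Compound 3 `COC(=O)N1CCC(Oc2ncnc3c2CCN3c2ccc(S(C)(=O)=O)cc2F)CC1`: 119%

Compound 3 stands second highest of these three values: a number 20 percentage points lower from compound 2 to compound 3 (beyond the scatter), while a number 28 percentage points higher from compound 1 to compound 3 (beyond the scatter). Compound 4 `CCOC(=O)N1CCC(Oc2ncnc3c2CCN3c2ccc(S(C)(=O)=O)cc2F)CC1` has not been measured. Its change from compound 3 is methyl in place of hydrogen on a saturated chain carbon bound to an oxygen next to a carbonyl group. One measured step is of the same kind, a methyl in place of hydrogen on that carbon, though on a larger chain: a number 48 percentage points higher from compound 1 to compound 2 (beyond the scatter). That step alone would point upward. Yet the three values show no steady run with the size of the group on the oxygen, since compound 3 lies above compound 1 and below compound 2. Taken together, the expectation for compound 4 is a step close to the scatter, leaning slightly upward: a number 3 percentage points higher from compound 3 to compound 4 (within the scatter). Compound 4 is therefore estimated at 122%, within a range from 90% to 150%.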

Compound 4, largest response reached (reported as percent of maximum), in percent of the reference or control that the assay uses: 135%
Compound 4: middle estimate off by 13 percentage points, on the low side; low and high end bracket the measured number.
By their numbers in this assay, from the lowest: compound 1; then compound 3; then compounds 4 and 2 (each within the scatter of the next).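

In this assay, adding one methyl on this carbon raises the response on a second parent as well (a number 16 percentage points higher from compound 3 to compound 4 (beyond the scatter)), so the rise seen earlier was not a single case. The direction holds, but the size of the gain depends on the group that receives the methyl: the same change on two cores in this assay, a number 48 percentage points higher (beyond the scatter) from compound 1 to compound 2 and a number 16 percentage points higher (beyond the scatter) from compound 3 to compound 4, 32 percentage points apart, beyond the scatter of two such steps. The ethyl and tert-butyl groups on the oxygen give matching responses (a number 4 percentage points lower from compound 2 to compound 4 (within the scatter)), while the isopropyl group stands apart (a number 44 percentage points higher from compound 1 to compound 4 (beyond the scatter)), so the isopropyl compound breaks any steady rise with chain size.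

What sets the isopropyl group apart stays unexplained by these compounds. From the compounds shown here alone, it also remains open whether a longer chain such as propyl or a ring such as cyclopropyl on that oxygen would behave like ethyl or like isopropyl.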